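Aryl exchange on the chain carbon: compound 3 to compound 4

A few compounds are considered here, and "the series" means these few. Any claim that something is new, unique, unknown or untested is made for them only; others in the source may bear on it.

In a functional assay on HeLa cells (Homo sapiens) for inhibition, read by MTT assay, with a stated time of 48 h (a lower number here means a stronger inhibitor, a higher number a weaker inhibitor), compound 1 (`O=C(CC(c1ccccc1)C(C(=O)Nc1ccccn1)C(=O)Nc1ccccn1)c1ccccc1`) gives 28100 nM and compound 2 (`O=C(CC(c1ccc(Cl)cc1)C(C(=O)Nc1ccccn1)C(=O)Nc1ccccn1)c1ccccc1`) gives 13600 nM. Within the data shown here, the only measured step, a 2.1-fold lower number from compound 1 to compound 2 (0.32 log units; beyond the scatter), is chloro in place of hydrogen on an aromatic carbon. It is modest but beyond the scatter. Compound 3 (`O=C(CC(c1c(Cl)cccc1Cl)C(C(=O)Nc1ccccn1)C(=O)Nc1ccccn1)c1ccccc1`) is reported as "not active" (no number reported), so it stands without a number and offers no fixed point from which to count a step.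

Compound 4 (`COc1ccc(C(CC(=O)c2ccccc2)C(C(=O)Nc2ccccn2)C(=O)Nc2ccccn2)cc1`) is not yet measured. The change from compound 3 to compound 4 is 4-methoxyphenyl in place of 2,6-dichlorophenyl on a saturated chain carbon bound to two saturated chain carbons. Among the measured compounds shown here, no measured step covers this exchange, and the size of a step starting from compound 3 cannot be stated. The step from compound 1 to compound 2 bears on it only loosely, as a single change on the same aryl group, while compound 3 shows that such a change can also end without a number. A measurable value remains the likelier outcome in this assay, in the region of compound 1 at 28100 nM and compound 2 at 13600 nM. For compound 4 the estimated value is 20000 nM, with an expected range of 8000 nM to 50000 nM.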

Compound 4, half-maximal inhibitory concentration: "not active" (no number reported)
The entry for compound 4 holds no number; there is nothing to compare the estimate with.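

In this assay compound 3 and compound 4 are both reported as "not active", so no step can be read between them. The compounds shown leave open how far either lies from compound 2 at 13600 nM, and whether the two aryl groups differ at all. No available evidence bears on this result.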